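The source may report more compounds than this note shows. Statements on the series, on what has been measured and on what is new or still open speak of the compounds shown alone.

In an ADME assay on HepG2 cells (Homo sapiens) for cytotoxicity, read by MTT assay, with a stated time of 24 h (a higher number here means that more compound is tolerated, a lower number that less compound is tolerated), compound 3 `CCN(CC)Cc1cn(-c2ccnc3cc(Cl)ccc23)nn1` gives 1850000 nM and compound 1 `Clc1ccc2c(-n3cc(-c4ccccc4)nn3)ccnc2c1` gives 574000 nM. Compound 2 `Clc1ccc2c(-n3cc(C4CCCCC4)nn3)ccnc2c1` gives only a limit, > 3200 nM. Compound 3 therefore holds the higher of the two actual numbers. Compound 4 `CN(C)Cc1cn(-c2ccnc3cc(Cl)ccc23)nn1` differs from compound 3 in one place: dimethylamino in place of diethylamino on a saturated chain carbon bound to an aromatic carbon. In words, dimethylamino stands in place of diethylamino on a saturated chain carbon bound to an aromatic carbon. Among the compounds with values here, the only readable step that bears on this is a 3.2-fold higher number from compound 1 to compound 3 (0.51 log units; beyond the scatter), which exchanged phenyl for the whole (diethylamino)methyl group. The present change is smaller and keeps the same kind of group, so no step beyond the scatter is expected in this assay. The expected step is a 1.2-fold lower number from compound 3 to compound 4 (0.06 log units; within the scatter). For compound 4 the estimate is 1600000 nM, within an expected range of 700000 nM to 3600000 nM.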

Compound 4, half-maximal cytotoxic concentration: 1850000 nM
Beside the measured number, compound 4's estimate is 1.2-fold (0.06 log units) below it; measured number inside the range.
By their numbers in this assay, from the lowest: compound 1; then compounds 3 and 4 (each within the scatter of the next).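

Exchanging diethylamino for dimethylamino on this saturated chain carbon gives no change at the digits printed from compound 3 to compound 4 (within the scatter), so at this position, removing these carbons from the amine leaves tolerance in the HepG2 read-out unchanged. The smaller amine also keeps the gain over phenyl, with a 3.2-fold higher number from compound 1 to compound 4 (0.51 log units; beyond the scatter). Steps involving compound 2 cannot be read, since its value is a limit: the limit of > 3200 nM in this assay, at which 1 of the 4 values shown sits.

On these data alone, whether a morpholine or a piperidine at this position would leave the number equally unchanged remains open. So does the effect of a longer chain carrying the amine.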